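Propyl in place of methyl on the shared core

The source may report more compounds than this note shows. Statements on the series, on what has been measured and on what is new or still open speak of the compounds shown alone.

Compound 1, `C[C@H](NC(=O)c1nnn(Cc2ccc(C(F)(F)F)cc2)c1C(F)(F)F)c1ccc(C(=O)O)cc1`: > 10000 nM
Compound 2, `C[C@H](NC(=O)c1c(C(F)(F)F)nnn1Cc1ccc(C(F)(F)F)cc1)c1ccc(C(=O)O)cc1`: 225 nM
Compound 3, `Cc1nnn(Cc2ccc(C(F)(F)F)cc2)c1C(=O)N[C@@H](C)c1ccc(C(=O)O)cc1`: > 10000 nM

Of the compounds shown here, three have been measured in a functional assay on CHO cells for antagonist activity at prostaglandin E2 receptor EP4 subtype (Homo sapiens), read by calcium flux, with a stated time of 15 min; a higher number here means a weaker inhibitor, a lower number a stronger inhibitor. Compound 2 gives 225 nM in this assay. For compound 1 the assay returns only a limit, > 10000 nM, not a number. Compound 3 likewise sits at a limit, > 10000 nM; compound 3 therefore stands at the weak end of what is shown, together with compound 1, and no ordering between those two can be read from their values. Among the measured compounds shown here, the one single-point step measured is an at least 44-fold higher number from compound 2 to compound 3 (1.64 log units; beyond the scatter), which places compound 3 at the limit of > 10000 nM in this assay, at which 2 of the 3 values shown sit.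

Compound 4, `CCCc1nnn(Cc2ccc(C(F)(F)F)cc2)c1C(=O)N[C@@H](C)c1ccc(C(=O)O)cc1`, has not been measured. It differs from compound 3 by ethyl in place of hydrogen on a saturated chain carbon bound to an aromatic carbon. For the measured compounds named here, no measured step concerns a change of this kind; the step from compound 2 to compound 3 shows only that the group on that aromatic carbon is consequential, and it is large. The step of an at least 1.2-fold lower number from compound 3 to compound 4 (0.09 log units; that floor lies within the scatter) is expected to be modest at best, and compound 4 is estimated at 8000 nM, within 1500 nM to 30000 nM.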

Compound 4, half-maximal inhibitory concentration: 68.8 nM
Beside the measured number, compound 4's estimate is 120-fold (2.07 log units) above it, outside the stated range (below it).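

In this assay, among the compounds shown here, the group on this aromatic carbon turns out to do more than the earlier compounds revealed: going from methyl to propyl, with ethyl in place of hydrogen on a saturated chain carbon bound to an aromatic carbon, gives an at least 140-fold lower number from compound 3 to compound 4 (2.16 log units; beyond the scatter). The earlier step showed only that methyl in place of trifluoromethyl costs activity, whereas a 3.3-fold lower number from compound 2 to compound 4 (0.51 log units; beyond the scatter) shows that trifluoromethyl is not required here, as a plain propyl chain in its place reads stronger in this assay. The step from methyl to propyl is known only as a minimum, as one of its ends is a limit of the assay and not a number: the limit of > 10000 nM in this assay, at which 2 of the 4 values shown sit.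

The compounds shown leave open how the number changes along the chain, whether ethyl already gives much of the gain and whether butyl or a longer chain goes further. They also leave open whether a branched group such as isopropyl, a ring such as cyclopropyl, or a chain carrying an amine or an ether oxygen would be accepted on that aromatic carbon.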